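The source may hold more compounds than are shown below. What is called first, only, known or untested is meant among the compounds shown, and "the series" means these compounds.

compound 1 `COc1cccc(C(=O)NNC(=O)c2ccc3[nH]c(-c4ccc([N+](=O)[O-])o4)nc3c2)c1`: 31.3 ug/mL
compound 2 `O=C(NNC(=O)c1ccc2[nH]c(-c3ccc([N+](=O)[O-])o3)nc2c1)c1cccc(Oc2ccccc2)c1`: > 7.8 ug/mL

For the measured compounds named here, in an ADME assay on Vero cells (Chlorocebus sabaeus) for inhibition, read by sulforhodamine B assay, with a stated time of 48 h (on this read-out lower numbers stand for stronger inhibition of growth and higher numbers for weaker inhibition of growth), compound 1 gives 31.3 ug/mL, the only true number so far, so it cannot yet be ranked against anything. Compound 2 gives > 7.8 ug/mL, which is a limit and not a number.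

Compound 3 `COc1ccc(C(=O)NNC(=O)c2ccc3[nH]c(-c4ccc([N+](=O)[O-])o4)nc3c2)cc1OC` has not been measured. Its difference from compound 1 is this: methoxy in place of hydrogen on an aromatic carbon. The ring thus goes from 3-methoxyphenyl to 3,4-dimethoxyphenyl.

Going by the values given here, the one measured step on this ring is a step that the limit leaves unreadable from compound 1 to compound 2, so it offers no size to carry over. With only the value of compound 1 at 31.3 ug/mL as an anchor, no shift beyond the usual scatter is expected in this assay, in either direction. The expected change is a 1.0-fold lower number from compound 1 to compound 3 (0.02 log units; within the scatter). For compound 3 the estimate is 30 ug/mL, with an expected range from 12 ug/mL to 75 ug/mL.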

Compound 3, concentration for 50% growth inhibition: 62.5 ug/mL
Compound 3: middle estimate off by 2.1-fold (0.32 log units), on the low side, and the stated range covers the measured number.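

In this assay, for the compounds shown here, the only step on this ring that can be read is a 2.0-fold higher number from compound 1 to compound 3 (0.30 log units; within the scatter), so the new methoxy group, ortho to a methoxy group and para to a large group, gives no shift that stands out from repeat measurements. The 3-methoxyphenyl and 3,4-dimethoxyphenyl rings therefore cannot be told apart on this read-out. The other step on this ring cannot be read, since compound 2 is reported only as a limit: the limit of > 7.8 ug/mL in this assay, at which 1 of the 3 values shown sits.

On these data alone, whether an amine or a carboxylic acid on this same aromatic carbon would move the number beyond the usual scatter stays open. So does whether a methoxy group on another carbon of this ring would behave the same way.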